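A few compounds are considered here, and "the series" means these few. Any claim that something is new, unique, unknown or untested is made for them only; others in the source may bear on it.

Of the compounds shown here, two sharing one core have been tested in an assay on membranes from CHO cells for displacement of a labelled ligand from adenosine receptor A1 (Homo sapiens), read by scintillation counting, with a stated time of 60 min, tested at 1 uM; a higher number here means more inhibition at the concentration tested (going by the name of the read-out), a lower number less inhibition. Compound 1 `CC1=C(C(=O)OC(C)(C)C)C(c2ccoc2)NC(=O)N1` gives 11%. Compound 2 `COC(=O)C1=C(C)NC(=O)NC1c1cccs1` gives 6% in this assay, a number that lies within the usual scatter of that of compound 1, so the two cannot be told apart on these data. Compound 3 `CC1=C(C(=O)OCc2ccccc2)C(c2cccs2)NC(=O)N1` has not yet been measured. It differs from compound 2 in one place: phenyl in place of hydrogen on a saturated chain carbon bound to an oxygen next to a carbonyl group. For the measured compounds named here, no pair of measured compounds shows what such a change does, so the step in this assay is expected to be small, a number 9 percentage points higher from compound 2 to compound 3 (within the scatter). Compound 3 is therefore estimated to give 15% in this assay, in the range 0% to 40%.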

Compound 3, a percentage reported as inhibition, at one concentration (the size of the read-out at that concentration, not a potency): 45%
Compound 3: middle estimate off by 30 percentage points, on the low side; measured number above the stated range.
By their numbers in this assay, from the lowest: compounds 2 and 1 (each within the scatter of the next); then compound 3.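

In this assay the change from methyl to benzyl gives a number 39 percentage points higher from compound 2 to compound 3 (beyond the scatter) and so lies beyond the scatter. For the compounds shown here, this is the first step between measured compounds that differ in one place, and it shows that what sits at this position affects the inhibition at the concentration tested. No measurement here gives a reason for this step. Still open, on these data alone, is whether the phenyl ring itself matters, or whether a longer chain such as butyl would do the same. An amine or a carboxylic acid on that phenyl is equally untested in these data.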